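The compounds below may be only part of what the source reports. "The series", "measured", "known", "first", "only" and "open" are said of these compounds alone.

Series notes. Compound 1 `O=C1OC(c2cccc3ccccc23)CN1C1CCN(Cc2cc3ccccc3[nH]2)CC1` and compound 2 `COc1ccc2nccc(C3CN(C4CCN(Cc5ccc6ccccc6c5)CC4)C(=O)O3)c2c1` share the oxazolidinone–piperidine core and have both been run in an in vitro functional assay on RBL cells for antagonist activity at C-C chemokine receptor type 8 (Homo sapiens), read by FLIPR and calcium flux; a higher number here means a weaker inhibitor, a lower number a stronger inhibitor. For compound 1 the result is only a limit of the assay, < 50200 nM, so it yields no number. Within the data shown here, compound 2 gives 1260 nM and is the sole numerical value in the set; the remaining entry sits at the limit of < 50200 nM in this assay, at which 1 of the 2 values shown sits. Compound 3 `COc1ccc2nccc(C3CN(C4CCN(Cc5ccccc5Cl)CC4)C(=O)O3)c2c1` is not yet measured and differs from compound 2 by 2-chlorophenyl in place of naphthalen-2-yl on a saturated chain carbon bound to an amine nitrogen in a ring. Among the measured compounds shown here, with no measured step of this kind available, a moderate loss of inhibition is expected, a 3.2-fold higher number from compound 2 to compound 3 (0.50 log units; beyond the scatter). Compound 3 is estimated at 4000 nM, within the range 1000 nM to 16000 nM.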

Compound 3, half-maximal inhibitory concentration: < 50200 nM
Compound 3 gave a limit, no number; the forecaster's own chance of this, stated with the estimate: 20%; the middle value is on the limit's open side.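

Among these compounds, for compound 3 the result is the limit < 50200 nM and not a number, so no step from compound 2 to compound 3 can be read. In this assay, as far as these compounds go, the size and direction of the change from naphthalen-2-yl to 2-chlorophenyl remain open.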